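The source may hold more compounds than are shown below. What is called first, only, known or untested is meant among the compounds shown, and "the series" means these compounds.

In an ADME assay on HUVEC cells (Homo sapiens) for cytotoxicity, read by MTT assay, with a stated time of 72 h (on this read-out higher numbers stand for weaker inhibition and lower numbers for stronger inhibition), compound 1 `CCCCCn1ccnc1-c1cc(OC)c(OC)c(OC)c1` gives "not determined" (no result reported) and so adds nothing to the comparison. Compound 2 `COc1cc(-c2nccn2-c2cccc(C)c2)cc(OC)c1OC` gives > 100000 nM as a limit and not a number. Compound 3 `COc1ccc(-n2ccnc2-c2cc(OC)c(OC)c(OC)c2)cc1` gives > 50000 nM as a limit too, so it has no measured number of its own. Among the compounds with values here, the only measured step that the two limits leave unreadable from compound 2 to compound 3 has no size that could be carried over to another change. Compound 4 `COc1ccc(-n2ccnc2-c2cc(OC)c(OC)c(OC)c2)cc1O` differs from compound 3 by hydroxy in place of hydrogen on an aromatic carbon with the new group ortho to a methoxy group and meta to a large group. Within the data shown here, no measured step involves this change, so the data fix no size for it. Compound 3 offers only a limit as a starting point, and a readable result for compound 4 would most likely lie on the side of stronger inhibition. An estimated at least 25-fold lower number from compound 3 to compound 4 (1.39 log units; beyond the scatter) is therefore expected, in that direction and with wide uncertainty. For compound 4 the estimate is 2000 nM with an expected range from 20 nM to 60000 nM given how little the data fix.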

Compound 4, half-maximal inhibitory concentration: 54200 nM
For compound 4 the middle estimate is 27-fold (1.43 log units) below the measured one; low and high end bracket the measured number.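

The step from compound 3 to compound 4 cannot be read, since compound 3 stands only at a limit: the limit of > 50000 nM in this assay, at which 1 of the 4 values shown sits. The compounds shown leave open how large a change hydroxy in place of hydrogen on an aromatic carbon brings, and how the groups on the aromatic nitrogen compare.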